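A few compounds are considered here, and "the series" means these few. Any claim that something is new, unique, unknown or untested is made for them only; others in the source may bear on it.

Compound 1 `CCCOP(=O)(O)OCCSC(=S)N1CCCC1` gives 73000 nM in a functional assay on MCF7 cells (Homo sapiens) for inhibition, read by MTT assay, with stated times of 18 h and 4 h; on this read-out lower numbers stand for stronger inhibition and higher numbers for weaker inhibition.
Compound 2 `CCCCCCOP(=O)(O)OCCSC(=S)N1CCCCC1` gives 62000 nM in this assay.
Compound 3 `CCCCCCOP(=O)(O)OCCSC(=S)N1CCN(C)CC1` gives 58000 nM in this assay.

Compound 1 stands highest of the three numbers, yet its gaps to compound 2 and compound 3 both lie within the scatter. Compound 4 `CCCCCCCCOP(=O)(O)OCCSC(=S)N1CCCC1` differs from compound 1 by pentyl in place of hydrogen on a saturated chain carbon, three bonds along the chain from an oxygen on an unsaturated carbon. Within the data shown here, no measured pair isolates a change of this kind: compound 1 and compound 2 differ in two places, and their values sit within the scatter of each other, while a 1.1-fold lower number from compound 2 to compound 3 (0.03 log units; within the scatter) concerns the ring and not the chain. Since the lengthening of this chain has no clear effect in these data, a step of a 1.2-fold lower number from compound 1 to compound 4 (0.09 log units; within the scatter) is expected, none beyond the scatter. Compound 4 is estimated at 60000 nM, in the range 25000 nM to 150000 nM.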

Compound 4, half-maximal inhibitory concentration: 53000 nM
Compound 4: the middle estimate sits 1.1-fold (0.05 log units) above what was measured; the measured number falls inside the stated range.
By their numbers in this assay, from the lowest: compounds 4, 3, 2 and 1 (each within the scatter of the next).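

With the ring held the same, the chain change alone, pentyl in place of hydrogen on a saturated chain carbon, gives a 1.4-fold lower number from compound 1 to compound 4 (0.14 log units; within the scatter) in this assay. Among these compounds, this is the first single-place reading of the chain, and it shows that adding this pentyl leaves the number within the scatter. No measurement here bears on why the number does not clearly move. Still open, from the compounds shown here alone, is whether a still longer chain, or an amine or a carboxylic acid at the end of this chain, would give a step beyond the scatter.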